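The compounds below may be only part of what the source reports. "The series", "measured", "known", "first", "only" and "open" are said of these compounds alone.

In an assay on isolated protein for inhibition of Fatty-acid amide hydrolase 1 (Rattus norvegicus), with a stated time of 3 h (on this read-out higher numbers stand for weaker inhibition and lower numbers for stronger inhibition), compound 1 `O=C(NCCCCc1ccccc1)n1cccn1` gives 290 nM. Compound 2 `Cc1cnn(C(=O)OCCCCc2ccccc2)c1` reaches only a limit in this assay, > 5000 nM, so its place among the numbers shown is given by the limit of > 5000 nM in this assay, at which 1 of the 2 values shown sits, and not by a measured figure. Compound 3 `N#Cc1cnn(C(=O)OCCCCc2ccccc2)c1` differs from compound 2 by cyano in place of methyl on an aromatic carbon. Among the measured compounds shown here, no measured step joins these two compounds. In this assay the expected step, toward stronger inhibition and well beyond the usual scatter, is an at least 12-fold lower number from compound 2 to compound 3 (1.09 log units; beyond the scatter). Compound 3 is estimated at 400 nM, within a range from 80 nM to 3000 nM.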

Compound 3, inhibition constant: 210 nM
Estimate against measurement, compound 3: 1.9-fold (0.28 log units) above; measured number inside the range.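

Among the compounds shown here, on this aromatic carbon, two ring bonds from the ring nitrogen, the earlier compounds gave no step, and in this assay cyano in place of methyl now gives an at least 23-fold lower number from compound 2 to compound 3 (1.37 log units; beyond the scatter). This shows that the group at this one ring position can by itself move the read-out well beyond the usual scatter. The value of compound 2 is only a limit, so the step gives a minimum size and not an exact one: the limit of > 5000 nM in this assay, at which 1 of the 3 values shown sits.

From the compounds shown here alone, how a carboxylic acid, an amine or a longer chain would read at this carbon remains open. So does whether cyano would give a similar step on the core of compound 1.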